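The source may report more compounds than this note shows. Statements on the series, on what has been measured and on what is new or still open speak of the compounds shown alone.

Among the measured compounds shown here, compound 1 `COc1ccc(Cn2cc[nH]c2=S)cc1` gives 204000 nM in an assay on isolated protein for inhibition of Dopamine beta-hydroxylase (Rattus norvegicus) (on this read-out higher numbers stand for weaker inhibition and lower numbers for stronger inhibition), the second highest of the three numbers measured so far. Compound 2 `COc1ccc(Cn2cc[nH]c2=S)cc1OC` gives 339000 nM, and compound 3 `COc1ccc(Cn2cc[nH]c2=S)cc1C` gives 69200 nM in this assay. The step of a 1.7-fold higher number from compound 1 to compound 2 (0.22 log units; within the scatter) stays within the scatter, whereas the step of a 2.9-fold lower number from compound 1 to compound 3 (0.47 log units; beyond the scatter) is a modest gain, as is the step of a 4.9-fold lower number from compound 2 to compound 3 (0.69 log units; beyond the scatter). Compound 4 `O=[N+]([O-])c1ccc(Cn2cc[nH]c2=S)cc1` carries nitro in place of methoxy on an aromatic carbon. For the measured compounds named here, no measured step replaces the methoxy itself; the known steps only add or swap a group on another aromatic carbon, and one of them gave nothing beyond the scatter. Compound 4 is therefore expected to show no step beyond the scatter, a 1.0-fold lower number from compound 1 to compound 4 (0.01 log units; within the scatter). The estimate for compound 4 in this assay is 200000 nM, within a range from 70000 nM to 600000 nM.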

Compound 4, half-maximal inhibitory concentration: 52500 nM
Estimate against measurement, compound 4: 3.8-fold (0.58 log units) above, outside the stated range (below it).
By their numbers in this assay, from the lowest: compounds 4 and 3 (each within the scatter of the next); then compounds 1 and 2 (each within the scatter of the next).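

In this assay, the aromatic carbon holding the methoxy proves able to shift the number: nitro in place of methoxy gives a 3.9-fold lower number from compound 1 to compound 4 (0.59 log units; beyond the scatter). The earlier steps shown here changed another aromatic carbon and left the methoxy in place, so they could not show this. Nothing available explains why this swap gives a modest gain.

Going by these compounds, whether an amine or a carboxylic acid on this carbon would shift the number further remains open. A single swap also cannot show which feature of nitro matters.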